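A (Piperidin-1-yl)methyl Change on Compound 2

A few compounds are considered here, and "the series" means these few. Any claim that something is new, unique, unknown or untested is made for them only; others in the source may bear on it.

In a functional assay on LNCaP cells (Homo sapiens) for antiproliferative activity (a lower number here means a stronger inhibitor, a higher number a weaker inhibitor), compound 1 `Cn1ncc(Cl)c1-c1cc(C(=O)N[C@@H]2CN[C@H](CC(O)CO)C[C@H]2c2ccc(F)c(F)c2)oc1Cl` gives 100 nM while compound 2 `Cn1ncc(Cl)c1-c1cc(C(=O)N[C@@H]2CN[C@H](CC(O)CO)C[C@H]2c2ccc(Cl)c(Cl)c2)oc1Cl` gives 70 nM and compound 3 `Cn1ncc(Cl)c1-c1cc(C(=O)N[C@@H]2CN[C@H](CCO)C[C@H]2c2ccc(F)c(F)c2)oc1Cl` gives 60 nM in the same test, so compound 2 stands within the scatter of both others. Compound 4 `Cn1ncc(Cl)c1-c1cc(C(=O)N[C@@H]2CN[C@H](CCN3CCCCC3)C[C@H]2c2ccc(Cl)c(Cl)c2)oc1Cl` carries the change (piperidin-1-yl)methyl in place of 1,2-dihydroxyethyl on a saturated chain carbon bound to a saturated ring carbon relative to compound 2, which replaces 2,3-dihydroxypropyl with 2-(piperidin-1-yl)ethyl. For the measured compounds named here, two measured steps bear on this, both within the scatter: a 1.7-fold lower number from compound 1 to compound 3 (0.22 log units; within the scatter) for hydrogen in place of hydroxymethyl on the chain and a 1.4-fold lower number from compound 1 to compound 2 (0.15 log units; within the scatter) for 3,4-dichlorophenyl in place of 3,4-difluorophenyl. Going by the values given here, no measured compound carries the (piperidin-1-yl)methyl group, so guidance is limited, and no step beyond the scatter is expected in this assay for this change. The expected size is a 1.2-fold lower number from compound 2 to compound 4 (0.07 log units; within the scatter) with wide uncertainty. Compound 4 is estimated at 60 nM within a range from 20 nM to 180 nM overall.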

Compound 4, half-maximal inhibitory concentration: 1780 nM
Beside the measured number, compound 4's estimate is 30-fold (1.47 log units) below it; measured number above the stated range.
By their numbers in this assay, from the lowest: compounds 3, 2 and 1 (each within the scatter of the next); then compound 4.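

In this assay, for the compounds shown here, the one earlier change on this chain stayed within the scatter, so the position looked tolerant, but the replacement of 1,2-dihydroxyethyl by (piperidin-1-yl)methyl gives a 25-fold higher number from compound 2 to compound 4 (1.41 log units; beyond the scatter). Going by these compounds alone, this position therefore does not accept every side chain, and this change counts for far more than the earlier steps did.

Nothing available explains the step. From the compounds shown here alone, whether it follows from the piperidine ring or from the loss of 1,2-dihydroxyethyl stays open, as does what a morpholine ring or a dimethylamino group would give on this chain.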